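Methoxy for chloro on the nitro-bearing enone series

The source may report more compounds than this note shows. Statements on the series, on what has been measured and on what is new or still open speak of the compounds shown alone.

Within the pair measured in a functional assay on HPC cells (Homo sapiens) for cytotoxicity (a higher number here means that more compound is tolerated, a lower number that less compound is tolerated), compound 2 `O=C1/C(=C/c2ccc(Cl)cc2)CCC/C1=C\c1ccc([N+](=O)[O-])cc1` gives 345000 nM, the higher of the two numbers. Compound 1 `COc1ccc(/C=C2\CCC/C(=C\c3ccc([N+](=O)[O-])cc3)C2=O)cc1OC` gives 82000 nM, and the gap between these two lies beyond the scatter. Compound 3 `COc1ccc(/C=C2\CCC/C(=C\c3ccc([N+](=O)[O-])cc3)C2=O)cc1` has not been measured. Compound 3 differs from compound 2 by methoxy in place of chloro on an aromatic carbon, para to a large group. Going by the values given here, no step between measured compounds covers this exact change, so the expectation rests on compound 1, which carries a methoxy at the same place together with a second one. A downward step of moderate size is expected for compound 3, a 2.2-fold lower number from compound 2 to compound 3 (0.33 log units; beyond the scatter), because compound 1 gives 82000 nM. In this assay compound 3 is estimated at 160000 nM, with a range from 60000 nM to 400000 nM.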

Compound 3, half-maximal cytotoxic concentration: > 400000 nM
Compound 3: only a limit was reported (the forecaster's own chance of this, stated with the estimate: 5%); at least 2.5-fold (0.39 log units) between middle value and limit.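

In this assay compound 3 gives > 400000 nM, which is a limit and not a number. For the change from 4-chlorophenyl to 4-methoxyphenyl, para to a large group, the series shows an at least 1.1-fold higher number from compound 2 to compound 3 (0.06 log units; that floor lies within the scatter), so methoxy here gives no drop in the number, though the floor alone does not fix the direction of the step. Hydrogen in place of methoxy on an aromatic carbon gives an at least 4.8-fold higher number from compound 1 to compound 3 (0.68 log units; beyond the scatter), so the low number seen with two methoxy groups does not carry over to the single methoxy para to a large group.

On these data alone, how far compound 3 lies past its limit remains open, and with it the true size of both steps. Also open, as far as these compounds go, is whether an amine or a carboxylic acid at this same place, or any change to the nitro-bearing ring, would bring the number back within the range of the assay.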